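Extending Compound 3 with a (Propanoylamino)methyl Group

The compounds below may be only part of what the source reports. "The series", "measured", "known", "first", "only" and "open" are said of these compounds alone.

Measured so far in an assay on cells for inhibition of cytochrome P450 11B2, mitochondrial (Homo sapiens), read by HTRF; a higher number here means a weaker inhibitor, a lower number a stronger inhibitor:
compound 1 `N#Cc1ccc2c(c1)CN(c1cccnc1)C2=O` gives 232 nM
compound 2 `CC1c2cc(Cl)ccc2C(=O)N1c1cccnc1` gives 123 nM
compound 3 `CC1(C)c2cc(Cl)ccc2C(=O)N1c1cccnc1` gives 108 nM

Compound 3 gives the lowest number of the three in this assay, but its distance to compound 2 is within the scatter, so the two cannot be ranked against each other; only compound 1, the furthest, lies beyond the scatter from compound 3.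

Compound 4 `CCC(=O)NCc1cncc(N2C(=O)c3ccc(Cl)cc3C2(C)C)c1` has not yet been measured. It differs from compound 3 in one place: (propanoylamino)methyl in place of hydrogen on an aromatic carbon

For the measured compounds named here, the only measured step, a 1.1-fold lower number from compound 2 to compound 3 (0.06 log units; within the scatter), concerns methyl in place of hydrogen on a saturated ring carbon and does not touch the aromatic ring carrying the new group. Going by the values given here, no measured pair speaks to a substituent entering on the aromatic carbon two atoms from the ring nitrogen, so nothing in the data points in either direction. In the absence of a bearing step, the expectation for compound 4 is a step of a 1.0-fold higher number from compound 3 to compound 4 (0.01 log units; within the scatter), that is, no change beyond the scatter.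

Compound 4 is therefore estimated at 110 nM in this assay, with a range from 40 nM to 320 nM.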

Compound 4, half-maximal inhibitory concentration: 282 nM
The estimate for compound 4 lay 2.6-fold (0.41 log units) below the measured number, and the stated range covers the measured number.
By their numbers in this assay, from the lowest: compounds 3, 2, 1 and 4 (each within the scatter of the next, the first and the last beyond it).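

The (propanoylamino)methyl group is the first substituent among the compounds shown on the aromatic carbon two atoms from the ring nitrogen, and in this assay it brings a 2.6-fold higher number from compound 3 to compound 4 (0.42 log units; beyond the scatter) as a modest step beyond the scatter. This position therefore responds to substitution, though the entry of a chain of 6 heavy atoms with an amide carbonyl and an amide hydrogen shifts the number only modestly, and compound 4 still gives a measured value of 282 nM in this assay rather than a limit. Nothing measured here bears on why the number moves in this direction.

The compounds shown leave open which part of the new group goes with the step, since a plain aminomethyl amine, an acetylamino chain, a longer chain or a carboxylic acid on the same carbon could separate the contribution of the amide from that of the chain length. They also leave open whether the same group would bring a step of similar size on the core of compound 2 or on another carbon of the same aromatic ring.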